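A few compounds are considered here, and "the series" means these few. Any claim that something is new, unique, unknown or untested is made for them only; others in the source may bear on it.

Values in a functional assay on NCI-H460 cells (Homo sapiens) for cytotoxicity, read by MTT assay, with a stated time of 68 h (on this read-out lower numbers stand for stronger inhibition and higher numbers for weaker inhibition), follow.
- compound 1 `O=C(Nc1cccc(-c2ccccc2C(F)(F)F)c1)C(Cl)Cl` gives 7550 nM as a number
- compound 2 `O=C(Nc1cccc(-c2ccccn2)c1)C(Cl)Cl` gives > 50000 nM as a limit
- compound 3 `CSc1ccc(-c2cc(NC(=O)C(Cl)Cl)cc(-c3ccc(SC)cc3)c2)cc1` gives > 30000 nM as a limit

Compound 1 is the only one of the three with a number in this assay here. Compound 2 stands only as a limit, and compound 3 likewise has no number.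

The next compound to consider is compound 4 `O=C(Nc1cccc(-c2nccs2)c1)C(Cl)Cl` with 1,3-thiazol-2-yl in place of the pyridin-2-yl of compound 2, on an aromatic carbon meta to a ((dichloromethyl)carbonyl)amino group 1,3-thiazol-2-yl in place of pyridin-2-yl on an aromatic carbon in the otherwise shared structure.

Among the measured compounds shown here, no two measured compounds differ in one place, so this change has no measured precedent. No step beyond the usual scatter is therefore expected in this assay for this exchange, and no direction is favoured. The expectation leans on compound 2 with its limit of > 50000 nM as the only close reference. A limit rather than a number is a real possibility for compound 4 as well.

The expected change is an at least 1.2-fold lower number from compound 2 to compound 4 (0.09 log units; that floor lies within the scatter) as an estimate only. Compound 4 is estimated at 40000 nM with an expected range from 12000 nM to 80000 nM in this read-out.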

Compound 4, half-maximal inhibitory concentration: > 50000 nM
Compound 4 was reported as a limit; the forecaster's own chance of this, stated with the estimate: 50%; middle value at least 1.2-fold (0.09 log units) from the limit.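

In this assay compound 4 gives > 50000 nM, a limit and not a number. Compound 2 also stands only as a limit, so no step can be read between compound 2 and compound 4. The compounds shown leave open how far, if at all, 1,3-thiazol-2-yl and pyridin-2-yl differ on the shared core.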